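The compounds below may be only part of what the source reports. "The series", "measured", "known", "first", "only" and "open" are said of these compounds alone.

Measured so far:
compound 1, `Brc1cn2ccnc2c(-c2ccc3ncn(C4CCCCC4)c3c2)n1`, 10.2%
compound 2, `O=Cc1ccc(-c2cn3ccnc3c(-c3ccc4ncn(C5CCCCC5)c4c3)n2)cc1`, 54.5%

Compound 2 stands highest of the two numbers in a functional assay on NCI-H23 cells (Homo sapiens) for inhibition, read by sulforhodamine B assay, with a stated time of 48 h, tested at 10 uM (a higher number here means more inhibition at the concentration tested (going by the name of the read-out), a lower number less inhibition), and its nearest neighbour is compound 1, which lies a large distance below it. Among the compounds with values here, the one measured step, a number 44.3 percentage points higher from compound 1 to compound 2 (beyond the scatter), shows that putting a 4-formylphenyl group where the bromo atom stood raises inhibition well beyond the scatter.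

Compound 3, `Fc1ccc(-c2cn3ccnc3c(-c3ccc4ncn(C5CCCCC5)c4c3)n2)cc1`, has not been measured in this assay. It differs from compound 2 as follows: fluoro in place of formyl on an aromatic carbon. Within the data shown here, the phenyl ring that carried the gain from compound 1 to compound 2 stays in place; only the group on it changes, and no measured step speaks to that change directly. The step from compound 1 to compound 2 bears on it only by showing that the aryl group matters, so the expectation is that compound 3 keeps much of the activity of compound 2, with a modest drop as the more likely direction; the expected step is a number 12.5 percentage points lower from compound 2 to compound 3 (beyond the scatter). In this assay compound 3 is estimated at 42%, within a range of 18% to 66%.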

Compound 3, a percentage reported as inhibition, at one concentration (the size of the read-out at that concentration, not a potency): 2.36%
Compound 3: middle estimate off by 39.6 percentage points, on the high side; measured number below the stated range.
By their numbers in this assay, from the lowest: compounds 3 and 1 (each within the scatter of the next); then compound 2.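

In this assay, the phenyl ring at this position does not carry the activity by itself: the ring stays in place through a number 52.1 percentage points lower from compound 2 to compound 3 (beyond the scatter), and only the group on it changes, so the gain seen earlier depends on the formyl group rather than on the presence of an aryl ring alone. The step of a number 7.8 percentage points lower from compound 1 to compound 3 (within the scatter) confirms this from the other side, as a 4-fluorophenyl group in place of the bromo atom leaves the read-out within the scatter, and among these three compounds only the one with the 4-formylphenyl group stands apart. Nothing at hand explains why the formyl and fluoro groups differ so sharply.

The compounds shown leave open whether the effect is specific to the formyl group or would also appear with an acetyl group, a methyl ester, a nitrile, a carboxylic acid, a hydroxymethyl group or an amine on the same ring carbon. They also leave open whether a formyl group elsewhere on the phenyl ring would give the same inhibition.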